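A Methyl in Place of Fluorine on the Aryl Arm

The compounds below may be only part of what the source reports. "The series", "measured", "known", "first", "only" and "open" are said of these compounds alone.

Of the compounds shown here, three on one shared core have been measured in a functional assay on PC-3 cells (Homo sapiens) for cytotoxicity, read by MTT assay, with a stated time of 72 h; a higher number here means a weaker inhibitor, a lower number a stronger inhibitor. Compound 1 `COc1cc(/C=C/C(=O)/C=C/C2=C(C)CCCC2(C)C)ccc1O` gives 21300 nM. Compound 2 `CC1=C(/C=C/C(=O)/C=C/c2cccc(C(F)(F)F)c2)C(C)(C)CCC1` gives 7700 nM. Compound 3 `CC1=C(/C=C/C(=O)/C=C/c2cccc(F)c2)C(C)(C)CCC1` gives 18700 nM. On these numbers compound 3 stands second highest of the three; its nearest neighbour is compound 1, which lies within the scatter of it, and its furthest is compound 2, which lies beyond the scatter. Within the data shown here, the one measured step between neighbours, a 2.4-fold higher number from compound 2 to compound 3 (0.39 log units; beyond the scatter), came from fluoro in place of trifluoromethyl on an aromatic carbon.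

Compound 4 `CC1=C(/C=C/C(=O)/C=C/c2cccc(C)c2)C(C)(C)CCC1` has not been measured. It differs from compound 3 by methyl in place of fluoro on an aromatic carbon. Among the measured compounds shown here, no measured step exchanges fluoro for methyl anywhere in this set, so the only guidance is that swap of one small group for another on the same aromatic carbon, a 2.4-fold higher number from compound 2 to compound 3 (0.39 log units; beyond the scatter), which was modest. A like-sized step, in either direction or none beyond the scatter, is the most that can be read from it.

In this assay compound 4 is therefore expected to give 15000 nM, with a range from 7000 nM to 35000 nM. That estimate means a 1.2-fold lower number from compound 3 to compound 4 (0.10 log units; within the scatter), a step expected to stay within the scatter.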

Compound 4, half-maximal inhibitory concentration: 35000 nM
Estimate against measurement, compound 4: 2.3-fold (0.37 log units) below, within the range that was stated.
By their numbers in this assay, from the lowest: compound 2; then compounds 3, 1 and 4 (each within the scatter of the next).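

In this assay, methyl in place of fluoro on this aromatic carbon gives a 1.9-fold higher number from compound 3 to compound 4 (0.27 log units; within the scatter), so the measurement does not separate these two small groups at this position. Methyl in place of trifluoromethyl gives a 4.5-fold higher number from compound 2 to compound 4 (0.66 log units; beyond the scatter), which, read with a 2.4-fold higher number from compound 2 to compound 3 (0.39 log units; beyond the scatter), sets trifluoromethyl apart from both fluoro and methyl in this series of three compounds with one exchanged group, and this second separation was not available from a single step before. No measured information accounts for this separation of trifluoromethyl from the other two groups.

The compounds shown leave open whether another group on the same aromatic carbon, such as methoxy, a nitrile, an amine or a carboxylic acid, would give a number that stays with compound 2 or with compound 3 and compound 4. They also leave open whether the exchanges among fluoro, methyl and trifluoromethyl would give steps of similar size on another carbon of the six-membered aromatic ring, or with a hydroxy or methoxy group also present on that ring.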